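A few compounds are considered here, and "the series" means these few. Any claim that something is new, unique, unknown or untested is made for them only; others in the source may bear on it.

Measured in a functional assay on the whole organism with Scenedesmus acutus as the target, read by spectrophotometry; a higher number here means a weaker inhibitor, a lower number a stronger inhibitor:

- Compound 1 `Cc1cc(Cl)ccc1-n1c(=S)n2n(c1=S)CCCC2`: 85.1 nM
- Compound 2 `S=c1s/c(=N\c2ccc(Br)cc2)n2n1CCCC2`: 148 nM
- Compound 3 `COC(=O)CSc1cc(-n2c(=S)n3n(c2=S)CCCC3)c(F)cc1Cl`: 141 nM

Compound 2 stands level with compound 3 and compound 1, since its gaps to both lie within the usual scatter. Compound 4 `S=c1s/c(=N\c2ccccc2)n2n1CCCC2` differs from compound 2 in one place: hydrogen in place of bromo on an aromatic carbon. This puts hydrogen in place of bromo on an aromatic carbon, para to a large group.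

Going by the values given here, no measured pair shows this change, so its size can only be judged indirectly. Among the compounds with values here, compound 2 at 148 nM carries bromo, and no measured compound lacks a halogen on its aromatic ring. A moderate loss of strength in this assay is therefore expected, with an estimated 2.4-fold higher number from compound 2 to compound 4 (0.37 log units; beyond the scatter) towards a higher number. The estimated value for compound 4 is 350 nM, within a range of 130 nM to 1000 nM.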

Compound 4, half-maximal inhibitory concentration: 13800 nM
The estimate for compound 4 lay 39-fold (1.60 log units) below the measured number; the whole stated range lies below it.
By their numbers in this assay, from the lowest: compounds 1, 3 and 2 (each within the scatter of the next); then compound 4.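

Swapping bromo for hydrogen on this aromatic carbon, para to a large group, gives a 93-fold higher number from compound 2 to compound 4 (1.97 log units; beyond the scatter) in this assay, so this single atom matters far more than the earlier compounds could show. A change of only one heavy atom can therefore decide much of the strength of this series. Nothing available here explains why the step is so large.

As far as these compounds go, whether bromo itself is needed, or whether other groups could serve at this place, remains open. A methoxy group or an amine there would help to settle that.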